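The source may report more compounds than this note shows. Statements on the series, on what has been measured and on what is new or still open speak of the compounds shown alone.

The compounds measured so far in an assay for inhibition of 6-phosphofructo-2-kinase/fructose-2,6-bisphosphatase 3 (Homo sapiens), read by ADP-Glo, with a stated time of 2 h; a lower number here means a stronger inhibitor, a higher number a weaker inhibitor:
compound 1, `CN1CCC(NS(=O)(=O)c2ccccc2Nc2cc(-c3ccc4ccn(C)c4c3)c3nccnc3c2)C1`; compound 1 gives 33 nM;
compound 2, `Cn1ccc2ccc(-c3cc(Nc4cnccc4C(=O)NCc4cncnc4)cc4nccnc34)cc21`; compound 2 gives 106 nM.

Compound 2 holds the higher of the two numbers in this assay. Compound 1 sits lower, and the gap between them lies beyond the usual scatter of this assay. Among the measured compounds shown here, the two compounds share the same core but differ in several places at once, so no single step between them is recorded; only their two values can be set side by side.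

Compound 3, `Cn1ccc2ccc(-c3cc(Nc4cnccc4C(=O)NCC4COCCN4)cc4nccnc34)cc21`, has not yet been measured. It differs from compound 2 in one place: morpholin-3-yl in place of pyrimidin-5-yl on a saturated chain carbon bound to an amide-type nitrogen. An aromatic ring gives way to a non-aromatic ring that carries a hydrogen-bond donor, with the hetero-atom count unchanged. For the measured compounds named here, no measured pair in this set shows a change of this kind, so the expectation rests on compound 2 alone. For compound 3 the expected step is a 1.5-fold higher number from compound 2 to compound 3 (0.18 log units; within the scatter), small and toward a weaker inhibitor, possibly within the scatter. The estimate for compound 3 in this assay is 160 nM, with a range from 50 nM to 500 nM.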

Compound 3, half-maximal inhibitory concentration: 33 nM
For compound 3 the middle estimate is 4.8-fold (0.69 log units) above the measured one; the measured number lies below the stated range.
By their numbers in this assay, from the lowest: compounds 1 and 3 (each within the scatter of the next); then compound 2.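

In this assay, morpholin-3-yl in place of pyrimidin-5-yl on a saturated chain carbon bound to an amide-type nitrogen gives a 3.2-fold lower number from compound 2 to compound 3 (0.51 log units; beyond the scatter), a modest step toward a stronger inhibitor. The earlier compounds shown here differ in several places at once and could not isolate any single position, whereas this pair shows that the number responds to the ring held at this place, and that an aromatic ring there is not required to reach this level of inhibition. Nothing measured here bears on why the number falls.

The change swaps an aromatic ring for a non-aromatic one and also brings in a hydrogen-bond donor, and this single pair cannot separate those two features; a tetrahydropyran-3-yl ring, which has no ring amine, or a piperidin-3-yl ring at the same place would bear on that question. Also open, going by these compounds, is how the number would respond to a longer chain leading to the morpholin-3-yl ring, or to an open-chain amine in place of the ring.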